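Moving to 3-methylphenyl on the carbonyl carbon

The compounds below may be only part of what the source reports. "The series", "measured", "known", "first", "only" and "open" are said of these compounds alone.

The series shares a core in which a nitrophenyl hydrazone is joined to an aroyl hydrazide, and the aryl on the carbonyl carbon is varied. Compound 1 `COc1ccc(C(=O)N/N=C(C)/C=N/Nc2ccc([N+](=O)[O-])cc2)cc1` carries a 4-methoxyphenyl there. In an ADME assay on J774 cells (Mus musculus, strain BALB/c) for cytotoxicity, read by resazurin assay, with a stated time of 72 h (a lower number here means that less compound is tolerated, a higher number that more compound is tolerated), compound 1 gives > 100000 nM, which is a limit of the assay and not a number. Compound 2 `CC(/C=N/Nc1ccc([N+](=O)[O-])cc1)=N\NC(=O)c1ccccc1F` carries a 2-fluorophenyl. In this assay compound 2 gives > 100000 nM, again a limit of the assay. Within the data shown here, compound 3 `CC(/C=N/Nc1ccc([N+](=O)[O-])cc1)=N\NC(=O)c1ccc(O)cc1` carries a 4-hydroxyphenyl, and in this assay compound 3 gives 51000 nM, the only number among the three. The step from compound 1 to compound 2 is a step that the two limits leave unreadable from compound 1 to compound 2. The step of an at least 1.9-fold lower number from compound 1 to compound 3 (0.29 log units; that floor lies within the scatter) and the step of an at least 1.9-fold lower number from compound 2 to compound 3 (0.29 log units; that floor lies within the scatter) both rest on (the limit of > 100000 nM in this assay, at which 2 of the 3 values shown sit), so neither can be read as a true change. Compound 4 `CC(/C=N/Nc1ccc([N+](=O)[O-])cc1)=N\NC(=O)c1cccc(C)c1` differs from compound 1 by 3-methylphenyl in place of 4-methoxyphenyl on a carbonyl carbon. Among the measured compounds shown here, the steps that bear on this change are the two just named, and neither is readable beyond the scatter, so no step beyond the scatter is expected in this assay. Compound 4 is therefore expected to sit near the limit, with an estimate of 100000 nM, between 40000 nM and 300000 nM, which is the expected step of a number no higher from compound 1 to compound 4 (the limit leaves the size open) from compound 1.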

Compound 4, half-maximal cytotoxic concentration: > 100000 nM
Compound 4: a limit, no number; the forecaster's own chance of this, stated with the estimate: 60%; the middle value sits exactly at the limit.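

In this assay, 3-methylphenyl on the carbonyl carbon stands at the limit of the assay, as 4-methoxyphenyl and 2-fluorophenyl do, so the steps from compound 1 and from compound 2 to compound 4 cannot be read: the limit of > 100000 nM in this assay, at which 3 of the 4 values shown sit. Among these compounds, the only step that touches a number is an at least 1.9-fold higher number from compound 3 to compound 4 (0.29 log units; that floor lies within the scatter), so it does not show a true change at this position. The entering 3-methylphenyl has no hydrogen-bond acceptor and the leaving 4-methoxyphenyl has one, yet compound 1 and compound 4 both end at a limit, so this change shows no readable effect on the number here.

Going by these compounds, how far the true values of compound 1, compound 2 and compound 4 lie past the limit stays open, as does whether any group on the carbonyl carbon gives a number beyond the scatter from the limit. An aryl carrying an amine or a carboxylic acid, or a longer chain in place of the aryl, could test this, and the compounds shown say nothing about either.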